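The source may hold more compounds than are shown below. What is called first, only, known or untested is meant among the compounds shown, and "the series" means these compounds.

In a functional assay on A549 cells (Homo sapiens) for antiproliferative activity, read by MTT assay, with a stated time of 24 h (on this read-out lower numbers stand for stronger inhibition and higher numbers for weaker inhibition), compound 1 (`C=CCc1cc(-c2cccc(C(F)(F)F)c2)ccc1O`) gives 73000 nM. Compound 2 (`C=CCc1cc(C=O)c(OCC(=O)OCC)c(-c2ccc(OCC(=O)OCC)c(CC=C)c2)c1`) gives > 85800 nM, which is a limit and not a number. Compound 3 (`C=CCc1cc(-c2cccc([N+](=O)[O-])c2)ccc1OC`) gives > 100000 nM, which is also a limit and not a number. Compound 4 (`C=CCc1cc(-c2cccc([N+](=O)[O-])c2)ccc1O`) differs from compound 3 in one place, with hydrogen in place of methyl on an oxygen on an aromatic ring, that is, methoxy to hydroxy (hydrogen in place of methyl on an oxygen on an aromatic ring). For the measured compounds named here, no measured pair shows this change directly. Going by the values given here, the only guide is compound 1, which also carries a hydroxy and gives 73000 nM. A modest gain in inhibition is therefore expected, and the estimated move is an at least 1.6-fold lower number from compound 3 to compound 4 (0.22 log units; that floor lies within the scatter). For compound 4 the expected value is 60000 nM, with an estimated range from 25000 nM to 100000 nM.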

Compound 4, half-maximal inhibitory concentration: > 100000 nM
Compound 4 gave a limit, no number (the forecaster's own chance of this, stated with the estimate: 35%); at least 1.6-fold (0.22 log units) between middle value and limit.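

In this assay compound 3 and compound 4 both end at a limit and give no number, so the change from methoxy to hydroxy cannot be read, because the two sit at the same ceiling: the limit of > 100000 nM in this assay, at which 2 of the 4 values shown sit. A hydroxy alone therefore does not ensure a number: with nitro in place of trifluoromethyl on an aromatic carbon, the result is an at least 1.3-fold higher number from compound 1 to compound 4 (0.13 log units; that floor lies within the scatter).

As far as these compounds go, whether methoxy or hydroxy matters at all on this core stays open. Also open, from the compounds shown here alone, is how an amine or a carboxylic acid in place of nitro on an aromatic carbon would read in this assay.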